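The source may report more compounds than this note shows. Statements on the series, on what has been measured and on what is new or still open speak of the compounds shown alone.

Of the compounds shown here, three built on a shared core have been tested in a functional assay on MCF7 cells (Homo sapiens) for cytotoxicity, read by colony formation, with a stated time of 1 h; a lower number here means a stronger inhibitor, a higher number a weaker inhibitor. Compound 1 `COc1ccc(C2C(C#N)=C(N)Oc3nc(Nc4ccc(S(N)(=O)=O)cc4)sc32)cc1` gives 14800 nM in this assay. Compound 2 `COc1ccc(C2C(C#N)=C(/N=C/c3ccccc3Cl)Oc3nc(Nc4ccc(S(N)(=O)=O)cc4)sc32)cc1` gives 9110 nM, and compound 3 `COc1ccc(C2C(C#N)=C(/N=C/c3cccc(Br)c3)Oc3nc(Nc4ccc(S(N)(=O)=O)cc4)sc32)cc1` gives 8720 nM. The three numbers sit close together: a 1.6-fold lower number from compound 1 to compound 2 (0.21 log units; within the scatter), a 1.7-fold lower number from compound 1 to compound 3 (0.23 log units; within the scatter) and a 1.0-fold lower number from compound 2 to compound 3 (0.02 log units; within the scatter), so compound 3 cannot be set apart from either of the other two on these numbers.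

Compound 4 `COc1ccc(C2C(C#N)=C(/N=C/c3ccc([N+](=O)[O-])cc3)Oc3nc(Nc4ccc(S(N)(=O)=O)cc4)sc32)cc1` differs from compound 3 in one place: 4-nitrophenyl in place of 3-bromophenyl on a carbon with a double bond to nitrogen. The measured step that bears most directly on this change is the exchange of one halophenyl ring for another, which was a 1.0-fold lower number from compound 2 to compound 3 (0.02 log units; within the scatter). The two steps that replace the single nitrogen atom with a larger group, a 1.6-fold lower number from compound 1 to compound 2 (0.21 log units; within the scatter) and a 1.7-fold lower number from compound 1 to compound 3 (0.23 log units; within the scatter), also left the number nearly where it was. None of these steps gives grounds to expect a move beyond the scatter. Compound 4 is therefore expected to give about 8700 nM in this assay, within a range from 3500 nM to 22000 nM, a step estimated as a 1.0-fold lower number from compound 3 to compound 4 (0.00 log units; within the scatter).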

Compound 4, half-maximal inhibitory concentration: 7550 nM
Estimate against measurement, compound 4: 1.2-fold (0.06 log units) above, within the range that was stated.
By their numbers in this assay, from the lowest: compounds 4, 3, 2 and 1 (each within the scatter of the next).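

In this assay, among these compounds, a ring carrying a nitro group now stands where the earlier compounds carried a halophenyl ring, on the carbon with a double bond to nitrogen, and the number stays within the scatter of both (a 1.2-fold lower number from compound 3 to compound 4 (0.06 log units; within the scatter); a 1.2-fold lower number from compound 2 to compound 4 (0.08 log units; within the scatter)). The step from the core with only the single nitrogen atom at this place also stays within the scatter (a 2.0-fold lower number from compound 1 to compound 4 (0.29 log units; within the scatter)), so compound 4 cannot be set apart from any of the other three. No measurement is at hand that would explain why these numbers lie so close together.

From the compounds shown here alone, what an amine or a carboxylic acid on this ring would give remains open. Also open, going by these compounds, is whether 4-bromophenyl would read like 3-bromophenyl, or 3-nitrophenyl like 4-nitrophenyl.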